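Series notes: aryl swap on the pyrazoline nitrogen and phenyl

The source may hold more compounds than are shown below. What is called first, only, known or untested is meant among the compounds shown, and "the series" means these compounds.

Measured so far:
compound 1 `Cc1ccc(C2=NN(c3ccc([N+](=O)[O-])cc3)C(c3cn(-c4ccccc4)nc3-c3ccc(Cl)c(Cl)c3)C2)cc1` – 72.5%
compound 2 `CC(=O)N1N=C(c2ccc(C)cc2)CC1c1cn(-c2ccccc2)nc1-c1ccc(Cl)c(Cl)c1` – 59.5%
compound 3 `Clc1ccc(C2=NN(c3ccccc3)C(c3cn(-c4ccccc4)nc3-c3ccc(Cl)c(Cl)c3)C2)cc1` – 53.4%

In a functional assay on the whole organism (strain Wistar) for inhibition, with Rattus norvegicus as the target, read by paw edema, with stated times of 30 min and 60 min, at a dose of 50 mg/kg by the oral route (on this read-out lower numbers stand for less inhibition and higher numbers for more inhibition at the one dose given (going by the name of the read-out)), compound 3 stands lowest of the three numbers; the gap to compound 2 lies within the scatter, the gap to compound 1 beyond it. Compound 4 `Cc1ccc(C2=NN(c3ccccc3)C(c3cn(-c4ccccc4)nc3-c3ccc(Cl)c(Cl)c3)C2)cc1` is not yet measured. It differs from compound 3 by methyl in place of chloro on an aromatic carbon. Among the measured compounds shown here, the one measured step, a number 13 percentage points lower from compound 1 to compound 2 (beyond the scatter), concerns a different position and does not bear on this exchange. Compounds 1 and 4 share the 4-methylphenyl, yet compound 1 also differs at the ring nitrogen, so no clean comparison exists. The expected step of a number 2.6 percentage points higher from compound 3 to compound 4 (within the scatter) is therefore none beyond the scatter. Compound 4 is estimated at 56%, within 42% to 70%.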

Compound 4, a percentage reported as inhibition, in the whole organism at one dose (the size of the read-out at that dose, not a potency): 58.8%
Estimate against measurement, compound 4: 2.8 percentage points below, and the stated range covers the measured number.
By their numbers in this assay, from the lowest: compounds 3, 4 and 2 (each within the scatter of the next); then compound 1.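

In this assay, the change from 4-chlorophenyl to 4-methylphenyl gives a number 5.4 percentage points higher from compound 3 to compound 4 (within the scatter) at this site, so the two groups are not separated here. With the 4-methylphenyl held constant, a number 0.7 percentage points lower from compound 2 to compound 4 (within the scatter) for phenyl in place of acetyl on the ring nitrogen, while a number 13.7 percentage points lower from compound 1 to compound 4 (beyond the scatter) for hydrogen in place of nitro, leaving the nitro-bearing compound 1 apart from compound 4. Nothing available explains these steps. As far as these compounds go, whether an amine or a carboxylic acid in place of the nitro would hold the number remains open, as does whether the nitro step carries over to the 4-chlorophenyl compounds.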